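Naphthalen-1-yl at the acetal carbon of a dioxane acid

This account rests on a few compounds, and the source may have more. Where it says the series, first, only, none or still open, it means among the compounds named here.

Compound 1 `N#Cc1ccccc1C1OCC(C/C=C\CCC(=O)O)C(c2cccnc2)O1`: 54 nM
Compound 2 `O=C(O)CC/C=C\CC1COC(c2cccnc2)OC1c1cccnc1`: 220 nM

Of the compounds shown here, two have been measured in an assay for inhibition of Thromboxane-A synthase (Homo sapiens), using microsomes; on this read-out lower numbers stand for stronger inhibition and higher numbers for weaker inhibition. Compound 1 gives 54 nM, and compound 2 gives 220 nM, so compound 2 stands at the higher of the two numbers, its nearest neighbour being compound 1 at a 4.1-fold higher number from compound 1 to compound 2 (0.61 log units; beyond the scatter). Within the data shown here, the only measured step, a 4.1-fold higher number from compound 1 to compound 2 (0.61 log units; beyond the scatter), is the one that bears on compound 3 `O=C(O)CC/C=C\CC1COC(c2cccc3ccccc23)OC1c1cccnc1`, which differs from compound 2 by naphthalen-1-yl in place of pyridin-3-yl on a saturated ring carbon. That step shows that exchanging pyridin-3-yl on this saturated ring carbon for an aromatic carbon ring lowered the number modestly. Naphthalen-1-yl is also a carbon-only aromatic group at the same place, so a modest lowering of the number is expected, of about a 2.2-fold lower number from compound 2 to compound 3 (0.34 log units; beyond the scatter). Compound 3 is therefore estimated at 100 nM, with a range from 40 nM to 300 nM.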

Compound 3, half-maximal inhibitory concentration: 40 nM
Compound 3: the middle estimate sits 2.5-fold (0.40 log units) above what was measured, and the stated range covers the measured number.
By their numbers in this assay, from the lowest: compounds 3 and 1 (each within the scatter of the next); then compound 2.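

On the saturated ring carbon between two ring oxygen atoms, in this assay, naphthalen-1-yl in place of pyridin-3-yl gives a 5.5-fold lower number from compound 2 to compound 3 (0.74 log units; beyond the scatter), so the earlier drop in potency on moving to pyridin-3-yl is now seen from a second group, one with two aromatic rings of carbon only. Naphthalen-1-yl in place of 2-cyanophenyl gives a 1.4-fold lower number from compound 1 to compound 3 (0.13 log units; within the scatter), within the scatter, so this read-out does not separate these two groups at this position, even though one has a nitrile and the other a second ring. No measurement offered here accounts for these differences.

The compounds shown leave open how unsubstituted phenyl or naphthalen-2-yl would read at this carbon. Also open, on these data alone, is whether a longer chain in place of the 5-carboxypent-2-en-1-yl group would alter the picture in this assay.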